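The source may hold more compounds than are shown below. What is called first, only, known or untested is meant among the compounds shown, and "the series" means these compounds.

Measured compounds in a functional assay on RAW264.7 cells (Mus musculus) for inhibition, read by ELISA, with stated times of 1 h and 18 h, tested at 1 uM; a higher number here means a weaker effect of the compound at the concentration tested, a lower number a stronger effect:
- compound 1, `C=C1CC[C@H]2C(C)(C)CCC[C@]2(C)[C@H]1C/C=C1/C(=O)OC[C@H]1O`: 68.1%
- compound 2, `C=C1CC[C@H]2C(C)(C)CCC[C@]2(C)[C@H]1C/C=C1\CC(O)OC1=O`: 82.4%
- compound 3, `C=C1CC[C@H]2C(C)(C)CCC[C@]2(C)[C@H]1C/C=C1\CC(OC)OC1=O`: 79.1%

Compound 1 gives the lowest of the three numbers in this assay; compound 3 sits higher and compound 2 still further up, both gaps beyond the scatter, so compound 1 stands as the strongest of the measured set at this concentration. Among the compounds with values here, the only single-change step in the set is a number 3.3 percentage points lower from compound 2 to compound 3 (within the scatter), which lies within the scatter and concerns a methyl on an oxygen, not the geometry of the exocyclic double bond.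

Compound 4, `C=C1CC[C@H]2C(C)(C)CCC[C@]2(C)[C@H]1C/C=C1\C(=O)OC[C@H]1O`, differs from compound 1 only as follows: the two compounds have the same atoms and bonds and differ only in configuration as drawn: 1 of 5 stereo elements differ; a double bond is drawn E in compound 1 and Z in compound 4. Within the data shown here, no measured step touches the geometry of this double bond, so nothing in the set speaks for a shift in either direction. The step of a number 0.1 percentage points lower from compound 1 to compound 4 (within the scatter) is therefore expected to be none beyond the scatter, with a wide range to reflect the absence of precedent. Compound 4 is estimated at 68%, between 50% and 86%.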

Compound 4, a percentage reported as activity, at one concentration (the size of the read-out at that concentration, not a potency): 76.9%
Estimate against measurement, compound 4: 8.9 percentage points below, and the stated range covers the measured number.
By their numbers in this assay, from the lowest: compounds 1, 4, 3 and 2 (each within the scatter of the next, the first and the last beyond it).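

In this assay, changing the double bond from E to Z gives a number 8.8 percentage points higher from compound 1 to compound 4 (within the scatter), so at this position the geometry of the double bond has no effect that can be told from the scatter. Compound 1 therefore no longer stands apart as the strongest of the set, as it and compound 4 cannot be separated on this step. This is the first step in the series that touches the double bond, and it isolates that one feature: the fact that compounds 1 and 4 differ only in the configuration as drawn

As far as these compounds go, whether the same holds for compound 2 and compound 3 with the opposite double-bond geometry stays open, and a read-out at a single concentration gives no potency. Also open, from the compounds shown here alone, is what an amine or an acetate ester in place of the hydroxyl of compound 1 and compound 4 would do in this assay.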